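The source may report more compounds than this note shows. Statements on the series, on what has been measured and on what is new or still open speak of the compounds shown alone.

Among the measured compounds shown here, in a functional assay on ileum (Cavia porcellus) for antagonist activity, with a stated time of 30 s (on this read-out higher numbers stand for weaker inhibition and lower numbers for stronger inhibition), compound 2 `O=C(O)c1cc(=O)c2ccc(OCCCCCc3ccccc3)cc2o1` gives 0.6 ug/mL and stands lowest of the two numbers so far, while compound 1 `O=C(O)c1cc(=O)c2ccc(OCCCCCCCOc3ccccc3)cc2o1` gives 1.8 ug/mL on the same read-out. Compound 3 `CC(=O)c1ccc(OCCCCCOc2ccc3c(=O)cc(C(=O)O)oc3c2)cc1` carries 4-acetylphenoxy in place of phenyl on a saturated chain carbon, five bonds along the chain from an oxygen on an aromatic ring. For the measured compounds named here, one measured step bears on this, a 3.0-fold lower number from compound 1 to compound 2 (0.48 log units; beyond the scatter) with phenyl in place of 2-phenoxyethyl, and it is modest. Compound 3 shares a phenoxy-type chain end with compound 1, so a smaller move towards a higher number is expected in this assay and the estimated change is a 1.7-fold higher number from compound 2 to compound 3 (0.22 log units; within the scatter) with no clear separation from the scatter. For compound 3 the estimate is 1 ug/mL with an expected range from 0.35 ug/mL to 3 ug/mL on this read-out.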

Compound 3, half-maximal inhibitory concentration: 3.5 ug/mL
Compound 3: middle estimate off by 3.5-fold (0.54 log units), on the low side, outside the stated range (above it).
By their numbers in this assay, from the lowest: compound 2; then compounds 1 and 3 (each within the scatter of the next).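

In this assay, 4-acetylphenoxy in place of phenyl on this saturated chain carbon gives a 5.8-fold higher number from compound 2 to compound 3 (0.77 log units; beyond the scatter), which leaves compound 2 with the lowest number of the three. 4-Acetylphenoxy in place of 2-phenoxyethyl gives a 1.9-fold higher number from compound 1 to compound 3 (0.29 log units; within the scatter), so the chain ends of compound 1 and compound 3 are not separated on this read-out. Nothing at hand gives a reason for these steps. Open, on these data alone, is whether the acetyl group or the oxygen of 4-acetylphenoxy carries the step from phenyl; plain phenoxy at this chain end would bear on that, and an amine there would test a different kind of group.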